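The source may report more compounds than this note shows. Statements on the series, on what has been measured and on what is new or still open speak of the compounds shown alone.

Working notes on the series

Three amides on a shared core have been run in an ADME assay on PC-3 cells (Homo sapiens) for cytotoxicity, read by WST assay, tested at 100 uM (on this read-out lower numbers stand for less inhibition and higher numbers for more inhibition at the one concentration tested (going by the name of the read-out)), so far. Compound 1 `O=C(Nc1cccc(N2CCCC2=O)c1)C1CCCN(C(=O)c2cc(C(F)(F)F)cc(C(F)(F)F)c2)C1` gives 0%. Compound 2 `O=C(Nc1cccc(Oc2ccccn2)c1)C1CCCN(C(=O)c2cc(C(F)(F)F)cc(C(F)(F)F)c2)C1` gives 0%. Compound 3 `CC(=O)c1cccc(NC(=O)C2CCCN(C(=O)c3cc(C(F)(F)F)cc(C(F)(F)F)c3)C2)c1` gives 0%. Across these three the read-out did not move: no change at the digits printed from compound 1 to compound 2 (within the scatter), no change at the digits printed from compound 1 to compound 3 (within the scatter) and no change at the digits printed from compound 2 to compound 3 (within the scatter). Compound 3 therefore stands level with compounds 1 and 2 at the digits shown, with no member of the set separating from the others beyond the scatter.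

The next compound, compound 4 `O=C(c1ccccc1)c1cccc(NC(=O)C2CCCN(C(=O)c3cc(C(F)(F)F)cc(C(F)(F)F)c3)C2)c1`, differs from compound 3 by phenyl in place of methyl on a carbonyl carbon. Among the measured compounds shown here, the three measured steps all exchange the group on the aromatic carbon and none shifted the read-out; no measured step exchanges methyl for phenyl on a carbonyl carbon, so the comparison is indirect. Given that every exchange at this position so far left the read-out flat, the step from compound 3 to compound 4 is expected to be no change at the digits printed from compound 3 to compound 4 (within the scatter), none beyond the scatter. Compound 4 is accordingly estimated at 0%, with a range from -10% to 12%.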

Compound 4, a percentage reported as inhibition, at one concentration (the size of the read-out at that concentration, not a potency): 0%
Compound 4: the middle estimate sits on the measured number at the digits printed, and the stated range covers the measured number.
By their numbers in this assay, from the lowest: compounds 1, 2, 3 and 4 (each within the scatter of the next).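

In this assay, among the compounds shown here, the change of methyl to phenyl on a carbonyl carbon gives no change at the digits printed from compound 3 to compound 4 (within the scatter) and is the only step in the set made at this place, so a carbon-only six-membered aromatic ring can enter there without the read-out separating. Benzoyl on the aromatic carbon also stays level with the other groups held there: the exchange for (pyridin-2-yl)oxy gives no change at the digits printed from compound 2 to compound 4 (within the scatter) and the exchange for 2-oxopyrrolidin-1-yl gives no change at the digits printed from compound 1 to compound 4 (within the scatter) with nothing in the set standing apart. No supporting data bear on this result, and no explanation can be drawn from it.

With all four compounds level, nothing here shows which kind of group would move this read-out. An amine or a carboxylic acid on the phenyl of the benzoyl group, or a longer chain in place of methyl on the carbonyl carbon, remains an open case.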